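The source may report more compounds than this note shows. Statements on the series, on what has been measured and on what is new or still open speak of the compounds shown alone.

Compound 1 `COc1ccc(/C=C/C(=O)CC(C)=O)cc1`: 15800 nM
Compound 2 `Cc1cc(/C=C/c2ccc(O)c(O)c2)on1`: 3300 nM

In a functional assay on PC-3 cells (Homo sapiens) for cytotoxicity, read by MTT assay, with a stated time of 72 h (a higher number here means a weaker inhibitor, a lower number a stronger inhibitor), compound 2 gives 3300 nM, the lower of the two numbers and so the stronger result. The gap to compound 1, at 15800 nM, lies beyond the scatter. These two compounds do not form a step that differs in one place, so the data offer no direct measure for the change considered next. Compound 3 `Cc1cc(/C=C/c2ccc(O)cc2)on1` has not yet been measured. It departs from compound 2 by a single change, hydrogen in place of hydroxy on an aromatic carbon. In this assay, a moderate move toward a higher number, beyond the scatter, is expected, although a smaller change remains possible. The expected change is a 2.4-fold higher number from compound 2 to compound 3 (0.38 log units; beyond the scatter). For compound 3 the estimated value is 8000 nM, within an expected range of 3000 nM to 25000 nM.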

Compound 3, half-maximal inhibitory concentration: 50200 nM
Compound 3: the middle estimate sits 6.3-fold (0.80 log units) below what was measured; the measured number lies above the stated range.
By their numbers in this assay, from the lowest: compound 2; then compound 1; then compound 3.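

In this assay the step of a 15-fold higher number from compound 2 to compound 3 (1.18 log units; beyond the scatter) is large and lies beyond the scatter, so hydrogen in place of hydroxy on this aromatic carbon costs much of the activity seen with compound 2. Among the compounds shown here, this is the first change in one place in the set, and it gives a direct measure of this one position, which the gap between compound 1 and compound 2 could not. The hydroxy group that stays ortho to this position does not keep the number of compound 2 on its own, and nothing available here gives a reason for the loss.

On these data alone, whether the hydroxy itself is needed at this position, or whether a methoxy group, an amine or a fluorine atom would serve there as well, remains open. As far as these compounds go, the part played by the remaining hydroxy group also remains open.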